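A few compounds are considered here, and "the series" means these few. Any claim that something is new, unique, unknown or untested is made for them only; others in the source may bear on it.

Compound 1 `CCCOc1ccc(S(=O)(=O)N2CCC(N3CCC(C)CC3)CC2)cc1`: in a functional assay on DLD-1 cells (Homo sapiens) for antiproliferative activity, read by CellTiter-Glo, with a stated time of 72 h (a higher number here means a weaker inhibitor, a lower number a stronger inhibitor), compound 1 gives 452 nM.
Compound 2 `CCCCOc1ccc(S(=O)(=O)N2CCC(N3CCC(C)CC3)CC2)cc1`: in this assay compound 2 gives 2300 nM.

Among the compounds with values here, compound 2 holds the higher, that is weaker, of the two numbers; the only measured step is a 5.1-fold higher number from compound 1 to compound 2 (0.71 log units; beyond the scatter). Compound 3 `COc1ccc(-c2ccc(S(=O)(=O)N3CCC(N4CCC(C)CC4)CC3)cc2)cc1` arises from compound 2 by 4-methoxyphenyl in place of butoxy on an aromatic carbon. Within the data shown here, no measured step swaps a chain for an aromatic ring, so that single step bears on this change only loosely: it shows that enlarging the group at this position weakened the inhibitor once. The expected step in this assay is therefore small and of uncertain direction, as a 1.5-fold lower number from compound 2 to compound 3 (0.19 log units; within the scatter), with a wide range. Compound 3 is estimated at 1500 nM, between 300 nM and 8000 nM.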

Compound 3, half-maximal inhibitory concentration: 263 nM
Compound 3: middle estimate off by 5.7-fold (0.76 log units), on the high side; measured number below the stated range.
By their numbers in this assay, from the lowest: compounds 3 and 1 (each within the scatter of the next); then compound 2.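

In this assay, a ring can sit at this position without loss: 4-methoxyphenyl in place of butoxy gives an 8.7-fold lower number from compound 2 to compound 3 (0.94 log units; beyond the scatter), while in place of propoxy it gives a 1.7-fold lower number from compound 1 to compound 3 (0.24 log units; within the scatter), a step within the scatter. Adding heavy atoms here therefore does not always weaken the inhibitor, although the butoxy chain of compound 2 did. Nothing measured here explains this difference. Going by these compounds, whether the methoxy on the added ring matters stays open, as does how a plain phenyl, a pyridine ring or an amine would behave at this position.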